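A few compounds are considered here, and "the series" means these few. Any claim that something is new, unique, unknown or untested is made for them only; others in the source may bear on it.

Compounds measured so far in a functional assay on KG-1 cells (Homo sapiens) for cytotoxicity, read by luminescence and CellTiter-Glo, with a stated time of 3 days; on this read-out higher numbers stand for weaker inhibition and lower numbers for stronger inhibition:

- compound 1 `N#Cc1ccc(NC(=O)c2ccc(C(F)(F)F)cc2O)cc1`: 1440 nM
- compound 2 `Cc1cccc(O)c1C(=O)Nc1ccc(C#N)cc1`: 7940 nM
- compound 3 `N#Cc1ccc(NC(=O)c2cc(Cl)ccc2O)cc1`: 1860 nM

Compound 3 gives the second highest of the three numbers in this assay. Its nearest neighbour is compound 1, whose number is lower but within the scatter, so the two cannot be told apart on this read-out. Compound 2 gives the highest number of the set, and its gap to compound 3 lies beyond the scatter. Within the data shown here, no step between two measured compounds that differ in a single place is available, so there is nothing to calibrate the size of a single substituent change against.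

Compound 4 `N#Cc1ccc(NC(=O)c2ccccc2O)cc1` is not yet measured. It differs from compound 3 by hydrogen in place of chloro on an aromatic carbon. The chloro is removed and nothing takes its place beyond a hydrogen.

Among the measured compounds shown here, with no matching step on hand, the expectation rests on the fact that the two compounds with a substituent in this part of the ring, compound 1 and compound 3, sit at the lower end of the numbers. A loss of the chloro is expected to move the number upward, by a modest step of a 2.2-fold higher number from compound 3 to compound 4 (0.33 log units; beyond the scatter), likely beyond the scatter but not by a wide margin. Compound 4 is therefore estimated at 4000 nM, with a range from 1500 nM to 11000 nM.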

Compound 4, half-maximal inhibitory concentration: 5370 nM
Estimate against measurement, compound 4: 1.3-fold (0.13 log units) below; the measured number falls inside the stated range.
By their numbers in this assay, from the lowest: compounds 1 and 3 (each within the scatter of the next); then compounds 4 and 2 (each within the scatter of the next).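

In this assay, hydrogen in place of chloro on an aromatic carbon, para to a hydroxy group, gives a 2.9-fold higher number from compound 3 to compound 4 (0.46 log units; beyond the scatter), so this position now has a single-change comparison and the chloro counts for more than the scatter. Hydrogen in place of trifluoromethyl on an aromatic carbon gives a 3.7-fold higher number from compound 1 to compound 4 (0.57 log units; beyond the scatter), also beyond the scatter, whereas loss of the methyl gives a 1.5-fold lower number from compound 2 to compound 4 (0.17 log units; within the scatter), which lies within it. Compound 4 therefore serves as a common reference for the series: compound 1 and compound 3 each carry a lower number than it, while compound 2 goes against any general gain from a substituent on this ring and cannot be told apart from compound 4.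

Still open, as far as these compounds go, is how an amine, a carboxylic acid or a methoxy group would compare with chloro on this same aromatic carbon, para to a hydroxy group, and whether any of them would match the number of compound 3. The data offer no independent measurement that explains the size or the direction of these steps.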